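Removing one more methyl from the series: expected effect

A few compounds are considered here, and "the series" means these few. Any claim that something is new, unique, unknown or untested is made for them only; others in the source may bear on it.

Measured in a functional assay for inhibition, with Rattus norvegicus as the target; on this read-out higher numbers stand for weaker inhibition and lower numbers for stronger inhibition:
- compound 1 `CCCCc1cc(OC)c2c(OC)cccc2c1OC(C)=O`: 260 nM
- compound 2 `CCCCc1cc(OC)c2c(C)cc(C)c(C)c2c1OC(C)=O`: 11900 nM
- compound 3 `CCCCc1cc(OC)c2c(C)ccc(C)c2c1OC(C)=O`: 7350 nM

Compound 3 stands at the high end of these numbers together with compound 2, the two lying within the scatter of each other. Compound 1 gives 260 nM, well under compound 3 at 7350 nM.

Compound 4 `CCCCc1cc(OC)c2c(C)cccc2c1OC(C)=O` arises from compound 3 by hydrogen in place of methyl on an aromatic carbon, para to a methyl group.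

Within the data shown here, only one measured step is of the same kind, namely a 1.6-fold lower number from compound 2 to compound 3 (0.21 log units; within the scatter). On that single precedent, no step beyond the scatter is expected in this assay, and any shift would most likely be small and towards a lower number. The expected step is a 1.3-fold lower number from compound 3 to compound 4 (0.13 log units; within the scatter). With one precedent only, the range is kept wide.

Compound 4 is estimated at 5500 nM, with an expected range of 2000 nM to 12000 nM.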

Compound 4, half-maximal inhibitory concentration: 620 nM
Compound 4: the middle estimate sits 8.9-fold (0.95 log units) above what was measured, outside the stated range (below it).
By their numbers in this assay, from the lowest: compound 1; then compound 4; then compounds 3 and 2 (each within the scatter of the next).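

In this assay the step of a 12-fold lower number from compound 3 to compound 4 (1.07 log units; beyond the scatter) shows that the methyl para to a methyl group carries real weight, since hydrogen in its place moves the number far beyond the scatter. The same kind of replacement at another aromatic carbon gave only a 1.6-fold lower number from compound 2 to compound 3 (0.21 log units; within the scatter) in the earlier pair, so across these two steps the outcome of hydrogen in place of methyl depends on its place on the ring. The step of a 2.4-fold higher number from compound 1 to compound 4 (0.38 log units; beyond the scatter) adds that, once that methyl is gone, methoxy in place of the remaining methyl brings a further modest shift in the same direction.

Nothing available speaks to why the methyl para to a methyl group has so large an effect. Still open, on these data alone, is how an ethyl, a chlorine or a hydroxyl group would compare at either of these two aromatic carbons.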